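Urea series: fluoro for methoxy in cytotoxicity

The source may hold more compounds than are shown below. What is called first, only, known or untested is meant among the compounds shown, and "the series" means these compounds.

Measured in an ADME assay on HepG2 cells (Homo sapiens) for cytotoxicity, with a stated time of 72 h; on this read-out higher numbers stand for an effect only at larger amounts of compound and lower numbers for an effect already at smaller amounts:
- compound 1 `Cc1cc(NC(=O)Nc2ccc(F)cc2F)c2ccccc2n1`: 17000 nM
- compound 2 `COc1ccccc1NC(=O)Nc1cc(C)nc2ccccc12`: > 25000 nM

Compound 2 sits at the limit of > 25000 nM in this assay, at which 1 of the 2 values shown sits. As far as these compounds go, its entry is a limit and not a number, so the true value is unknown. Compound 3 `Cc1cc(NC(=O)Nc2ccccc2F)c2ccccc2n1` is still to be measured. It carries fluoro in place of methoxy on an aromatic carbon, ortho to a large group (fluoro in place of methoxy on an aromatic carbon). For the measured compounds named here, no measured step covers this change, so the expectation rests on compound 1, which gives 17000 nM. The expected step is an at least 1.2-fold lower number from compound 2 to compound 3 (0.09 log units; that floor lies within the scatter), and it is not expected to go beyond the scatter. For compound 3 the estimated value is 20000 nM, with an expected range of 10000 nM to 35000 nM.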

Compound 3, half-maximal effective concentration: > 25000 nM
Compound 3: no number, only a limit; the forecaster's own chance of this, stated with the estimate: 40%; at least 1.2-fold (0.09 log units) between middle value and limit.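

Compound 3, like compound 2, gives only a limit and not a number in this assay, so the step for fluoro in place of methoxy on this aromatic carbon, ortho to a large group, cannot be read: the limit of > 25000 nM in this assay, at which 2 of the 3 values shown sit.

For the compounds shown here, the only readable comparison involves compound 1, where hydrogen in place of fluoro on an aromatic carbon gives an at least 1.4-fold higher number from compound 1 to compound 3 (0.16 log units; that floor lies within the scatter). This floor does not show that the change has an effect beyond the scatter.

As far as these compounds go, the true values of compound 2 and compound 3 remain open, as does the direction of any difference between methoxy and fluoro at this position. An amine or a carboxylic acid on the same aromatic carbon could show whether this position moves the read-out at all.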